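The compounds below may be only part of what the source reports. "The series", "measured", "known", "first", "only" and "open" are said of these compounds alone.

In an in vitro ADME assay on microsomes from liver (Homo sapiens) for metabolic stability, read by LC-MS (a higher number here means that the compound lasts longer, a lower number that the compound disappears faster), compound 2 (`CC(C)N1C(=O)C(=O)N=C1/N=C(/Nc1ccc(Cl)c(Cl)c1)NC(C)(C)C`) gives > 1 h. That value is a limit of the assay and not a number. Compound 1 (`CC(C)N1C(=O)C(=O)N=C1/N=C(\NOCc1ccccc1)Nc1ccc(Cl)c(Cl)c1`) gives 0.215 h and compound 3 (`CCCCCCN/C(=N\C1=NC(=O)C(=O)N1C(C)C)Nc1ccc(Cl)c(Cl)c1`) gives 0.131 h, which lie within the scatter of each other. Measured against them, compound 2 lasts longest, with an at least 4.6-fold higher number from compound 1 to compound 2 (0.66 log units; beyond the scatter) and an at least 7.6-fold lower number from compound 2 to compound 3 (0.88 log units; beyond the scatter) both beyond the scatter.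

Compound 4 (`CC(C)N1C(=O)C(=O)N=C1/N=C(\NCCCN(C)C)Nc1ccc(Cl)c(Cl)c1`) keeps the shared core but changes the group on the amine nitrogen: 3-(dimethylamino)propyl in place of tert-butyl on an amine nitrogen. The closest guide is the change from tert-butyl to hexyl, since hexyl, like 3-(dimethylamino)propyl, is a chain with no ring. That change gave an at least 7.6-fold lower number from compound 2 to compound 3 (0.88 log units; beyond the scatter), so a drop of similar size, beyond the scatter, is expected here. Going by the values given here, the new chain also carries a nitrogen that hexyl lacks, and no measured compound shows what that does in this assay, so the range stays wide. The expected step is an at least 4.0-fold lower number from compound 2 to compound 4 (0.60 log units; beyond the scatter). Compound 4 is estimated at 0.25 h, with an expected range from 0.08 h to 0.8 h.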

Compound 4, half-life: > 1 h
Compound 4 ended at the assay's limit; the forecaster's own chance of this, stated with the estimate: 10%; middle value at least 4.0-fold (0.60 log units) away from the limit.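

In this assay, going by these compounds alone, the earlier compounds left open whether any chain with no ring on this amine nitrogen shortens the half-life, and compound 4 shows that it need not. With dimethylamino in place of propyl, three bonds along the chain from the amine nitrogen, the result is an at least 7.6-fold higher number from compound 3 to compound 4 (0.88 log units; beyond the scatter), so what sits along the chain matters and not only the absence of a ring. The same group set against benzyloxy gives an at least 4.6-fold higher number from compound 1 to compound 4 (0.66 log units; beyond the scatter).

The step between compound 2 and compound 4 cannot be read, because each of them stands at a limit and not at a number: the limit of > 1 h in this assay, at which 2 of the 4 values shown sit. The compounds shown also leave open whether a shorter chain carrying the same amine, or a chain ending in a carboxylic acid, would last as long.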